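Methoxy for fluoro on the benzyl group of compound 3

The source may report more compounds than this note shows. Statements on the series, on what has been measured and on what is new or still open speak of the compounds shown alone.

Measured so far:
compound 1 `O=C(NCc1cn(Cc2ccc(F)cc2)nn1)c1cn(-c2ccccc2)nc1-c1ccccc1`: 1600 nM
compound 2 `COc1cc(Cn2cc(CNC(=O)c3cn(-c4ccccc4)nc3-c3ccccc3)nn2)cc(OC)c1`: 12200 nM
compound 3 `O=C(NCc1cn(Cc2ccc(F)cc2)nn1)c1cn(-c2ccccc2)nc1-c1ccc(F)cc1`: 1200 nM

In a functional assay on HeLa cells (Homo sapiens) for antiproliferative activity, read by sulforhodamine B assay, with a stated time of 48 h (a lower number here means a stronger inhibitor of growth, a higher number a weaker inhibitor of growth), compound 3 gives the lowest of the three numbers, though it is within the scatter of compound 1 and separated from compound 2 by a step beyond the scatter. Compound 4 `COc1ccc(Cn2cc(CNC(=O)c3cn(-c4ccccc4)nc3-c3ccc(F)cc3)nn2)cc1` differs from compound 3 by methoxy in place of fluoro on an aromatic carbon, that is 4-fluorobenzyl to 4-methoxybenzyl. The step of a 1.3-fold lower number from compound 1 to compound 3 (0.12 log units; within the scatter) lies elsewhere and does not bear on this. The step of a 7.6-fold higher number from compound 1 to compound 2 (0.88 log units; beyond the scatter) also exchanges fluoro for methoxy groups on that benzyl carbon, though at different sites and with two of them, so a modest weakening is expected, a 2.9-fold higher number from compound 3 to compound 4 (0.46 log units; beyond the scatter). Compound 4 is therefore estimated at 3500 nM, within 1500 nM to 8000 nM.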

Compound 4, concentration for 50% growth inhibition: 870 nM
Beside the measured number, compound 4's estimate is 4.0-fold (0.60 log units) above it, and the stated range ends above it.
By their numbers in this assay, from the lowest: compounds 4, 3 and 1 (each within the scatter of the next); then compound 2.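

In this assay the change from 4-fluorobenzyl to 4-methoxybenzyl gives a 1.4-fold lower number from compound 3 to compound 4 (0.14 log units; within the scatter) and so costs nothing measurable at this position. The loss in a 7.6-fold higher number from compound 1 to compound 2 (0.88 log units; beyond the scatter) with 3,5-dimethoxyphenyl in place of 4-fluorophenyl is not repeated by a single methoxy para to a large group. No measurement given here explains this result. From the compounds shown here alone, what stays open is whether the loss with compound 2 follows from the number of methoxy groups or from their sites, and whether an amine or a carboxylic acid on this benzyl ring would be accepted as well.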